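Compound 2 to compound 4: isobutyl to sec-butyl

The source may report more compounds than this note shows. Statements on the series, on what has been measured and on what is new or still open speak of the compounds shown alone.

In an ADME assay on EA.hy 926 cells (Homo sapiens) for inhibition, read by sulforhodamine B assay, with a stated time of 72 h (a higher number here means a weaker inhibitor, a lower number a stronger inhibitor), compound 1 `COc1cc(/C=C/C(=O)/C=C(/C=C/c2ccc(OC(C)=O)c(OC)c2)NC2CCCCC2)ccc1OC(C)=O` gives > 25000 nM as a limit of the assay, not a number. Compound 2 `COc1cc(/C=C/C(=O)/C=C(/C=C/c2ccc(OC(C)=O)c(OC)c2)NCC(C)C)ccc1OC(C)=O` stands at > 25000 nM as a limit too, so no number fixes its place in the series. Compound 3 `CC(=O)Oc1ccc(/C=C/C(=O)/C=C(/C=C/c2ccc(OC(C)=O)cc2)NCC(C)C)cc1` gives > 25000 nM as a limit as well. Among the measured compounds shown here, the series so far shows the limit of > 25000 nM in this assay, at which 3 of the 3 values shown sit, and nothing more.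

Compound 4 `CCC(C)NC(=C\C(=O)/C=C/c1ccc(OC(C)=O)c(OC)c1)/C=C/c1ccc(OC(C)=O)c(OC)c1` differs from compound 2 by sec-butyl in place of isobutyl on an amine nitrogen as sec-butyl in place of isobutyl on an amine nitrogen. For the measured compounds named here, the one measured step at that nitrogen is a step that the two limits leave unreadable from compound 1 to compound 2 and offers no size to carry over. In this assay the expected step is a step that the limit leaves unreadable from compound 2 to compound 4 and nothing beyond the scatter is expected, in either direction. Compound 4 is estimated at 30000 nM with an expected range of 15000 nM to 60000 nM and will probably be reported only as a limit.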

Compound 4, half-maximal inhibitory concentration: > 25000 nM
Compound 4: a limit, no number (the forecaster's own chance of this, stated with the estimate: 85%); the middle value lies beyond the limit too.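

Among the compounds shown here, compound 4 gives > 25000 nM, a limit and not a number, and no step to it from compound 1 or compound 2 can be read. The compounds shown leave open whether any group on the amine nitrogen changes the inhibition.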